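Benzyl for Methyl on Two Thiosugar Nucleoside Cores

The source may report more compounds than this note shows. Statements on the series, on what has been measured and on what is new or still open speak of the compounds shown alone.

Compound 1 `CSc1nc2sncc2n1[C@H]1C[C@H](O)[C@@H](CO)O1` gives 6000 nM. Compound 2 `OC[C@H]1O[C@@H](n2c(SCc3ccccc3)nc3sncc32)C[C@@H]1O` gives 3000 nM. Compound 3 `CSc1nc2c(C)nsc2n1[C@@H]1O[C@H](CO)[C@@H](O)[C@H]1O` gives only a limit, > 100000 nM.

All three compounds were tested in a functional assay on KB cells (Homo sapiens) for antiproliferative activity; a higher number here means a weaker inhibitor, a lower number a stronger inhibitor. Compound 1 and compound 2 share one core, and compound 2 differs from compound 1 by phenyl in place of hydrogen on a saturated chain carbon bound to a sulfur. That change gave a 2.0-fold lower number from compound 1 to compound 2 (0.30 log units; within the scatter). Compound 3 rests on a different core; how the core of compound 3 differs from the core of compound 1 is not broken down here. For compound 3 the number is a limit, at which (the limit of > 100000 nM in this assay, at which 1 of the 3 values shown sits).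

Compound 4 `Cc1nsc2c1nc(SCc1ccccc1)n2[C@@H]1O[C@H](CO)[C@@H](O)[C@H]1O` has not yet been measured in this assay. It differs from compound 3 by phenyl in place of hydrogen on a saturated chain carbon bound to a sulfur, the same change that was made from compound 1 to compound 2, at the same place on both cores. Because the earlier step of a 2.0-fold lower number from compound 1 to compound 2 (0.30 log units; within the scatter) stayed within the scatter, the expected step is a number no higher from compound 3 to compound 4 (the limit leaves the size open), again within the scatter. Because compound 3 returned > 100000 nM, a limit, compound 4 is expected to return a limit as well. In this assay compound 4 is estimated at 100000 nM, with the expected range from 30000 nM to 300000 nM.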

Compound 4, half-maximal inhibitory concentration: > 100000 nM
Compound 4 ended at the assay's limit; the forecaster's own chance of this, stated with the estimate: 70%; the middle value lies on the limit itself.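

In this assay compound 4 gives > 100000 nM, which is a limit. Going by these compounds alone, compound 3 also rests on a limit, so no step between compound 3 and compound 4 can be read: the limit of > 100000 nM in this assay, at which 2 of the 4 values shown sit.

The compounds shown leave open whether methylsulfanyl to benzylsulfanyl changes anything on the core of compound 3, and whether that core would answer the change as the core of compound 1 does.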